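Shrinking the Amine: From Compound 2 to Compound 3

The source may report more compounds than this note shows. Statements on the series, on what has been measured and on what is new or still open speak of the compounds shown alone.

Among the measured compounds shown here, compound 2 `CN1CCN(CC(=O)O[C@@H]2C[C@@H]3CC[C@@]2(C)C3(C)C)CC1` gives 313000 nM in an ADME assay on HEK-293T cells (Homo sapiens) for cytotoxicity, read by MTT assay, with a stated time of 48 h (a higher number here means that more compound is tolerated, a lower number that less compound is tolerated), the higher of the two numbers measured so far, while compound 1 `CC1CCN(CC(=O)O[C@@H]2C[C@@H]3CC[C@@]2(C)C3(C)C)CC1` gives 71600 nM. For the measured compounds named here, the one step already known, a 4.4-fold higher number from compound 1 to compound 2 (0.64 log units; beyond the scatter), shows that exchanging the amine on the carbon next to the carbonyl can move the number beyond the scatter. Compound 3 `CN(C)CC(=O)O[C@@H]1C[C@@H]2CC[C@@]1(C)C2(C)C` carries the change (dimethylamino in place of 4-methylpiperazin-1-yl on a saturated chain carbon bound to a carbonyl carbon). Going by the values given here, only that earlier step bears on it, and it does not involve dimethylamino, so the direction is open. For compound 3 a modest step of a 2.1-fold lower number from compound 2 to compound 3 (0.32 log units; beyond the scatter) back toward the middle of the two measured values is expected. Compound 3 is therefore estimated at 150000 nM, between 50000 nM and 450000 nM.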

Compound 3, half-maximal cytotoxic concentration: 389000 nM
Compound 3: the middle estimate sits 2.6-fold (0.41 log units) below what was measured; low and high end bracket the measured number.
By their numbers in this assay, from the lowest: compound 1; then compounds 2 and 3 (each within the scatter of the next).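

In this assay, replacing 4-methylpiperazin-1-yl with dimethylamino gives a 1.2-fold higher number from compound 2 to compound 3 (0.09 log units; within the scatter), so at this place the number does not depend on keeping that six-membered ring. Dimethylamino in place of 4-methylpiperidin-1-yl gives a 5.4-fold higher number from compound 1 to compound 3 (0.74 log units; beyond the scatter), which leaves 4-methylpiperidin-1-yl alone apart from the other two amines. Nothing available explains why these amines fall this way. On these data alone, it remains open whether diethylamino, another open-chain amine, would stay level with dimethylamino. Morpholin-4-yl, a six-membered ring with oxygen in place of the second nitrogen, is also untested among these compounds.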